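The source may report more compounds than this note shows. Statements on the series, on what has been measured and on what is new or still open speak of the compounds shown alone.

Among the compounds with values here, in a functional assay on HeLa cells (Homo sapiens) for cytotoxicity, read by MTT assay, with a stated time of 72 h (a lower number here means a stronger inhibitor, a higher number a weaker inhibitor), compound 1 `O=C(/C=C/c1cccc(Cl)c1Cl)Nc1cc2c(Nc3ccc(F)c(Cl)c3)ncnc2cc1O[C@H]1CCOC1` gives 30500 nM and compound 2 `O=C(/C=C/c1cc(Br)c(O)c(Br)c1)Nc1cc2c(Nc3ccc(F)c(Cl)c3)ncnc2cc1O[C@H]1CCOC1` gives 27700 nM, so compound 2 sits level with the only other measured compound. Compound 3 `COc1cc(/C=C/C(=O)Nc2cc3c(Nc4ccc(F)c(Cl)c4)ncnc3cc2O[C@H]2CCOC2)cc(OC)c1` takes compound 2 and makes one structural change: 3,5-dimethoxyphenyl in place of 3,5-dibromo-4-hydroxyphenyl on a double-bonded chain carbon bound to a double-bonded chain carbon. This exact swap has not been measured. The nearest evidence is a 1.1-fold lower number from compound 1 to compound 2 (0.04 log units; within the scatter), where one substituted phenyl group replaced another at the same place and the result stayed within the scatter. On that single step, the change a 1.0-fold higher number from compound 2 to compound 3 (0.00 log units; within the scatter) is expected to stay within the scatter too. For compound 3, the estimated value is 28000 nM, with an expected range of 12000 nM to 60000 nM.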

Compound 3, half-maximal inhibitory concentration: 34300 nM
Compound 3: middle estimate off by 1.2-fold (0.09 log units), on the low side, and the stated range covers the measured number.
By their numbers in this assay, from the lowest: compounds 2, 1 and 3 (each within the scatter of the next).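

In this assay, 3,5-dimethoxyphenyl in place of 3,5-dibromo-4-hydroxyphenyl gives a 1.2-fold higher number from compound 2 to compound 3 (0.09 log units; within the scatter), and in place of 2,3-dichlorophenyl it gives a 1.1-fold higher number from compound 1 to compound 3 (0.05 log units; within the scatter). Three differently substituted phenyl groups at this place now stand level, even though the group entering has 0 hydrogen-bond donors where 3,5-dibromo-4-hydroxyphenyl has 1. Nothing on hand offers an explanation for this flat result. On these data alone, all three compounds carry a substituted phenyl here, so what a carboxylic acid or an amine at this place would do stays open.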